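Oxan-4-yl for difluorocyclohexyl on a CXCR4 antagonist amine

The compounds below may be only part of what the source reports. "The series", "measured", "known", "first", "only" and "open" are said of these compounds alone.

Measured compounds:
compound 1 `c1ccc2c(c1)CN[C@@H](CN(CCCCNC1CCCCC1)[C@H]1CCCc3cccnc31)C2` gives 75.2 nM
compound 2 `CC(C)(CCN(C[C@H]1Cc2ccccc2CN1)[C@H]1CCCc2cccnc21)CNC1CCC(F)(F)CC1` gives 168 nM

Of the compounds shown here, two have been measured in a functional assay on cells for antagonist activity at C-X-C chemokine receptor type 4 (Homo sapiens), read by fluorescence and calcium flux, with stated times of 25 min and 90 s; a higher number here means a weaker inhibitor, a lower number a stronger inhibitor. Compound 1 `c1ccc2c(c1)CN[C@@H](CN(CCCCNC1CCCCC1)[C@H]1CCCc3cccnc31)C2` gives 75.2 nM in this assay. Compound 2 `CC(C)(CCN(C[C@H]1Cc2ccccc2CN1)[C@H]1CCCc2cccnc21)CNC1CCC(F)(F)CC1` gives 168 nM in this assay, the higher of the two numbers; compound 1 sits at a lower number, and that gap lies beyond the scatter. The two compounds differ in more than one place, so no single step can be read between them.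

Compound 3 `CC(C)(CCN(C[C@H]1Cc2ccccc2CN1)[C@H]1CCCc2cccnc21)CNC1CCOCC1` has not yet been measured. It follows from compound 2 by a single change: oxan-4-yl in place of 4,4-difluorocyclohexyl on an amine nitrogen. The ring that leaves and the ring that enters are both six-membered and non-aromatic, differing in that two fluorines on carbon are exchanged for one oxygen in the ring, which brings one hydrogen-bond acceptor into the group. For the measured compounds named here, no measured step in this assay mirrors this exchange, so the direction is uncertain. Compound 3 is expected to land near compound 2, with at most a small shift in this assay, a 1.5-fold higher number from compound 2 to compound 3 (0.17 log units; within the scatter), not clearly beyond the scatter. The estimate for compound 3 is 250 nM, with a plausible range from 100 nM to 700 nM.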

Compound 3, half-maximal inhibitory concentration: 36.3 nM
Compound 3: the middle estimate sits 6.9-fold (0.84 log units) above what was measured, and the stated range ends above it.
By their numbers in this assay, from the lowest: compound 3; then compound 1; then compound 2.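

In this assay, for the compounds shown here, the amine substituent proves to be a position that responds clearly: oxan-4-yl in place of 4,4-difluorocyclohexyl gives a 4.6-fold lower number from compound 2 to compound 3 (0.67 log units; beyond the scatter), the first single change that can be read. The change also makes compound 3 the strongest inhibitor of the three, with a 2.1-fold lower number from compound 1 to compound 3 (0.32 log units; beyond the scatter), although that step replaces a larger group that takes in both the chain and the ring, so it does not isolate the effect of the ring. Nothing measured here accounts for the gain, and the step from 4,4-difluorocyclohexyl to oxan-4-yl alters the ring atoms, the heavy-atom count and the hydrogen-bond acceptor count together.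

The compounds shown leave open which of those differences matters, and a plain cyclohexyl or a piperidin-4-yl group on the same amine of the compound 3 scaffold would help to separate them. They also leave open how much of the step from compound 1 belongs to the chain and how much to the ring, and whether oxan-4-yl would give a similar step on the unbranched butyl chain of compound 1.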